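A few compounds are considered here, and "the series" means these few. Any claim that something is new, unique, unknown or untested is made for them only; others in the source may bear on it.

In a functional assay on HepG2 cells (Homo sapiens) for cytotoxicity, read by MTT assay, with a stated time of 72 h (on this read-out lower numbers stand for stronger inhibition and higher numbers for weaker inhibition), compound 1 `O=C(N/N=C/c1ccc(F)cc1Cl)Nc1cc2c(Nc3ccc(F)c(Cl)c3)ncnc2cc1O[C@H]1CCOC1` gives 26100 nM and compound 2 `CCN(CC)c1ccc(/C=N/NC(=O)Nc2cc3c(Nc4ccc(F)c(Cl)c4)ncnc3cc2O[C@H]2CCOC2)c(O)c1` gives 15700 nM as its reading. Compound 3 `COc1cc2ncnc(Nc3ccc(F)c(Cl)c3)c2cc1NC(=O)N/N=C/c1cccc(Br)c1` has no place on that numerical scale, since compound 3 is recorded as "not active" (no number reported) without a figure. Compound 4 `COc1cc2ncnc(Nc3ccc(F)c(Cl)c3)c2cc1NC(=O)N/N=C/c1cc(OC)c(OC)c(OC)c1` differs from compound 3 in one place, with 3,4,5-trimethoxyphenyl in place of 3-bromophenyl on a carbon with a double bond to nitrogen as the whole of the change. For the measured compounds named here, no measured step starts from compound 3, so only one step bears on this change. That step exchanges a different pair of groups at the same kind of carbon, and it amounts to a 1.7-fold lower number from compound 1 to compound 2 (0.22 log units; within the scatter) in size. On this single precedent, no shift beyond the scatter is expected from the exchange in this assay and a weak result is expected, possibly again without a figure. For compound 4 the estimate is 25000 nM with an expected range from 10000 nM to 80000 nM if a number is reported at all.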

Compound 4, half-maximal inhibitory concentration: 30100 nM
Beside the measured number, compound 4's estimate is 1.2-fold (0.08 log units) below it; measured number inside the range.
By their numbers in this assay, from the lowest: compounds 2, 1 and 4 (each within the scatter of the next).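

For the compounds shown here, compound 3 is recorded as "not active" without a figure, so no step from compound 3 to compound 4 can be read. The compounds shown leave open how far 3,4,5-trimethoxyphenyl in place of 3-bromophenyl shifts the reading. Nothing given here bears on a cause for these readings.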